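This account rests on a few compounds, and the source may have more. Where it says the series, first, only, none or still open, it means among the compounds named here.

In a functional assay on the whole organism for inhibition, with Mus musculus as the target, in the maximal electroshock model, at a dose of 30 mg/kg by the oral route (a lower number here means a weaker effect, a higher number a stronger effect of the compound at the dose given), three compounds with a shared core have been measured so far. Compound 1 `CC(C)N1C(=O)NC2(CC2(C)C)C1=O` gives 70%, compound 2 `CC1(C)CC12NC(=O)N(Cc1ccccc1)C2=O` gives 70%, and compound 3 `CC1(C)CC12NC(=O)N(c1ccccc1)C2=O` gives 80%. Compound 3 stands at the highest of the three numbers, yet compound 1 and compound 2 each lie within the usual scatter of it, so no order among the three can be claimed. Compound 4 `CC1(C)CC12NC(=O)N(c1ccc(F)cc1)C2=O` has not yet been measured in this assay. It differs from compound 3 in one place: fluoro in place of hydrogen on an aromatic carbon. For the measured compounds named here, no step between two measured compounds involves a change of this kind, so these data point to no shift in either direction. The expected step is no change at the digits printed from compound 3 to compound 4 (within the scatter), none beyond the scatter. Compound 4 is estimated at 80%, within a range from 55% to 100%.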

Compound 4, a percentage reported as inhibition, in the whole organism at one dose (the size of the read-out at that dose, not a potency): 80%
The estimate for compound 4 equals the measured number at the digits printed, within the range that was stated.
By their numbers in this assay, from the lowest: compounds 1, 2, 3 and 4 (each within the scatter of the next).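

In this assay, the first step read at this position is no change at the digits printed from compound 3 to compound 4 (within the scatter) and shows that fluoro in place of hydrogen on an aromatic carbon, para to a large group, leaves the read-out at this dose intact. The earlier compounds shown here held no change on this ring, so they could not show this. No measurement on hand accounts for the result.

As far as these compounds go, whether a chlorine atom, a methoxy group or an amine at this place would do the same remains open. A single dose gives no potency, so any difference in potency between these two compounds also stays unresolved.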